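A Bromo Substituent Added to the Amide of Compound 2

The source may hold more compounds than are shown below. What is called first, only, known or untested is meant among the compounds shown, and "the series" means these compounds.

Compound 1 `O=C(CCCCC1CCSS1)NO` carries a hydroxamic acid on the shared core; in a functional assay on HO8910 cells (Homo sapiens) for inhibition, read by MTT assay, with a stated time of 24 h, tested at 100 ug/mL (on this read-out higher numbers stand for more inhibition of growth at the one concentration tested and lower numbers for less inhibition of growth), compound 1 gives "not active" (no number reported), with no figure reported. Compound 2 `O=C(CCCCC1CCSS1)Nc1ccccn1` replaces it with an aromatic amine, and in this assay compound 2 gives 51.9%, the only number shown among the two measured compounds. Compound 3 `O=C(CCCCC1CCSS1)Nc1ccc(Br)cn1` differs from compound 2 only by bromo in place of hydrogen on an aromatic carbon, the new group sitting two atoms from the ring nitrogen. Going by the values given here, no step between measured compounds is available to guide the size of this change, so it is expected to remain within the scatter, a number 3.1 percentage points higher from compound 2 to compound 3 (within the scatter). Compound 3 is therefore expected to give about 55% in this assay, between 35% and 75%.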

Compound 3, percent growth inhibition at one concentration: 32.1%
Estimate against measurement, compound 3: 22.9 percentage points above; measured number outside the range, below it.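

Placing bromo on the aromatic carbon para to a large group, two atoms from the ring nitrogen, is not a neutral change in this assay: it gives a number 19.8 percentage points lower from compound 2 to compound 3 (beyond the scatter), a drop beyond the scatter. Going by these compounds alone, this shows for the first time that inhibition of growth responds to a change at this position of the ring. Nothing available here accounts for the drop.

Going by these compounds, whether fluoro, chloro, an amine or a carboxylic acid at this position would lower inhibition as bromo does remains open. So does whether bromo on another carbon of the ring would have the same effect.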